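This account rests on a few compounds, and the source may have more. Where it says the series, first, only, none or still open, it means among the compounds named here.

Measured compounds, read in a functional assay on CHO cells for antagonist activity at prostaglandin E2 receptor EP3 subtype (Homo sapiens), read by cAMP accumulation; a higher number here means a weaker inhibitor, a lower number a stronger inhibitor:
- compound 1 `CC(C)C(c1nnc[nH]1)c1ccc(-c2ccc3cccc(F)c3c2)[nH]c1=O`: 21 nM
- compound 2 `CC(C)NC(=O)CC(c1ccc(-c2ccc3cccc(F)c3c2)[nH]c1=O)C(C)C`: 15 nM
- compound 3 `CC(C)C(/C=C1\CCNC1=O)c1ccc(-c2ccc3cccc(F)c3c2)[nH]c1=O`: 8.7 nM

Compound 3 holds the lowest of the three numbers in this assay. One step, a 1.7-fold lower number from compound 2 to compound 3 (0.24 log units; within the scatter), does not separate the two compounds it joins, while the other, a 2.4-fold lower number from compound 1 to compound 3 (0.38 log units; beyond the scatter), is a modest but real difference. The three compounds share the same core and differ only in the group on the saturated chain carbon bound to an aromatic carbon and a saturated chain carbon.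

Compound 4 `Cc1nc(C(c2ccc(-c3ccc4cccc(F)c4c3)[nH]c2=O)C(C)C)[nH]c1C` is the next variation at that same place. The change from compound 3 is a group of 7 heavy atoms (5 carbon, 2 nitrogen; one five-membered aromatic ring with 2 hetero atoms) in place of a group of 7 heavy atoms (5 carbon, 1 nitrogen, 1 oxygen; one five-membered non-aromatic ring with 1 hetero atom), on a saturated chain carbon bound to an aromatic carbon and a saturated chain carbon. The step that bears on it most is a 2.4-fold lower number from compound 1 to compound 3 (0.38 log units; beyond the scatter), where a five-membered aromatic ring with hetero atoms at this position gave the higher number and the non-aromatic ring the lower one. Compound 4 returns to a five-membered aromatic ring with hetero atoms, so a step back toward the number of compound 1 is expected, though the two aromatic rings are not the same and the size of the effect is uncertain; a 1.4-fold lower number from compound 1 to compound 2 (0.15 log units; within the scatter) shows that non-ring groups here also sit close to compound 1. The expected step is therefore a 1.8-fold higher number from compound 3 to compound 4 (0.26 log units; within the scatter), upward and near the edge of the scatter. Compound 4 is expected at 16 nM, within 6 nM to 45 nM.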

Compound 4, half-maximal inhibitory concentration: 50 nM
Beside the measured number, compound 4's estimate is 3.1-fold (0.49 log units) below it; the measured number lies above the stated range.
By their numbers in this assay, from the lowest: compounds 3, 2 and 1 (each within the scatter of the next, the first and the last beyond it); then compound 4.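

In this assay the 4,5-dimethyl-1H-imidazol-2-yl group gives the weakest inhibitor of the four, with each step beyond the scatter: against the five-membered non-aromatic ring (a 5.7-fold higher number from compound 3 to compound 4 (0.76 log units; beyond the scatter)), against the (isopropylcarbamoyl)methyl group (a 3.3-fold higher number from compound 2 to compound 4 (0.52 log units; beyond the scatter)) and against the 4H-1,2,4-triazol-3-yl group (a 2.4-fold higher number from compound 1 to compound 4 (0.38 log units; beyond the scatter)). The groups exchanged between compound 3 and compound 4 match in heavy atoms, hydrogen-bond donors and hydrogen-bond acceptors, yet their numbers differ beyond the scatter, and the two five-membered aromatic rings of compound 1 and compound 4 also do not read alike, so neither these counts nor the presence of such a ring sets the number at this place. Nothing available explains the rise seen with the new group.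

Open, from the compounds shown here alone, is whether the step belongs to the imidazole ring itself or to its two methyl groups, a question that an unsubstituted 1H-imidazol-2-yl group would address. Also open, going by these compounds, is how a primary amine or a carboxylic acid would read on this saturated chain carbon bound to an aromatic carbon and a saturated chain carbon.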